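A Bromine Replaces a Methyl on the Benzyl Ether

The source may hold more compounds than are shown below. What is called first, only, known or untested is meant among the compounds shown, and "the series" means these compounds.

Measured so far in an ADME assay on Vero cells (Chlorocebus sabaeus) for cytotoxicity, read by sulforhodamine B assay, with a stated time of 72 h; on this read-out higher numbers stand for weaker inhibition and lower numbers for stronger inhibition:
compound 1, `CN1Cc2ccc(OCc3ccc([N+](=O)[O-])cc3)cc2[C@@H](O)C1`: > 50000 nM
compound 2, `Cc1cccc(COc2ccc3c(c2)[C@@H](O)CN(C)C3)c1`: > 50000 nM
compound 3, `CN1Cc2ccc(OCc3ccc(Oc4ccc(F)cc4)cc3)cc2[C@@H](O)C1`: 5600 nM

Compound 2 stands at a limit of the assay, not at a number. Compound 1 also sits at that limit, (the limit of > 50000 nM in this assay, at which 2 of the 3 values shown sit). Among the measured compounds shown here, compound 3 gives a numbered value, and the one measured step, an at least 8.9-fold lower number from compound 1 to compound 3 (0.95 log units; beyond the scatter), involves a different group at a different place, so it bears only loosely on the change at hand. Compound 4, `CN1Cc2ccc(OCc3cccc(Br)c3)cc2[C@@H](O)C1`, differs from compound 2 by bromo in place of methyl on an aromatic carbon. With one small group exchanged for another, no step beyond the scatter is expected, and another limit is the likelier outcome. Compound 4 is therefore estimated at 50000 nM, within 20000 nM to 200000 nM. The step from compound 2 to compound 4 is expected to be a number no higher from compound 2 to compound 4 (the limit leaves the size open).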

Compound 4, half-maximal inhibitory concentration: 60300 nM
For compound 4 the middle estimate is 1.2-fold (0.08 log units) below the measured one; measured number inside the range.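

No step can be read from compound 2 to compound 4, because the value of compound 2 is a limit and not a number: the limit of > 50000 nM in this assay, at which 2 of the 4 values shown sit.

The compounds shown leave open whether bromo in place of methyl changes the number in this assay at all.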